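The compounds below may be only part of what the source reports. "The series", "measured", "known", "first", "only" and "open" are said of these compounds alone.

Measured so far:
- compound 1, `Cc1ccc(-c2nn(-c3ccccc3)cc2-c2nc3ccccc3n2C(=O)c2cncc(C)c2)cc1`: 155000 nM
- compound 2, `Cc1ccc(-c2nn(-c3ccccc3)cc2-c2nc3ccccc3n2C(=O)c2cccc(C)c2)cc1`: 195000 nM
- compound 3, `O=C(c1cccnc1)n1c(-c2cn(-c3ccccc3)nc2-c2ccc(C(F)(F)F)cc2)nc2ccccc21`: 158000 nM

In an ADME assay on HEK-293T cells (Homo sapiens) for cytotoxicity, read by MTT assay, with a stated time of 24 h (a lower number here means that less compound is tolerated, a higher number that more compound is tolerated), compound 3 gives 158000 nM, and all three numbers lie within the usual scatter of one another, so none can be set apart. Compound 4, `Cc1ccc(-c2nn(-c3ccccc3)cc2-c2nc3ccccc3n2C(=O)c2cccnc2)cc1`, differs from compound 3 by methyl in place of trifluoromethyl on an aromatic carbon. Among the measured compounds shown here, no measured step touches this group; the only measured step, a 1.3-fold higher number from compound 1 to compound 2 (0.10 log units; within the scatter), altered the carbonyl side and stayed within the scatter. No step beyond the scatter is therefore expected in this assay, in either direction. For compound 4 the expected number is 165000 nM, with a range of 95000 nM to 280000 nM, which corresponds to the estimated step of a 1.0-fold higher number from compound 3 to compound 4 (0.02 log units; within the scatter).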

Compound 4, half-maximal cytotoxic concentration: 189000 nM
For compound 4 the middle estimate is 1.1-fold (0.06 log units) below the measured one; the measured number falls inside the stated range.
By their numbers in this assay, from the lowest: compounds 1, 3, 4 and 2 (each within the scatter of the next).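

In this assay, among the compounds shown here, methyl in place of trifluoromethyl on the aromatic carbon gives a 1.2-fold higher number from compound 3 to compound 4 (0.08 log units; within the scatter) and is the first measured change at this position, so 4-(trifluoromethyl)phenyl and 4-methylphenyl cannot be told apart here. On the carbonyl side, pyridin-3-yl in place of 3-methylphenyl gives a 1.0-fold lower number from compound 2 to compound 4 (0.01 log units; within the scatter) and hydrogen in place of methyl on the pyridine gives a 1.2-fold higher number from compound 1 to compound 4 (0.09 log units; within the scatter) as well.

From the compounds shown here alone, whether an amine or a carboxylic acid at this position would move the number beyond the scatter remains open. No measurement at hand offers a reason for these results.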